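From carboxy to ethoxycarbonyl at the assay limit

The compounds below may be only part of what the source reports. "The series", "measured", "known", "first", "only" and "open" are said of these compounds alone.

In a functional assay on HCT-116 cells (Homo sapiens) for cytotoxicity, read by MTT assay, with a stated time of 72 h (on this read-out lower numbers stand for higher toxicity in this test and higher numbers for lower toxicity in this test), compound 1 (`Cn1c(=O)c(C(=O)O)c(O)c2cc(Cc3ccc(F)cc3)ccc21`) gives > 10000 nM as a limit, not a number. Compound 2 (`Cn1c(=O)c(C(=O)O)c(O)c2cc(Oc3ccccc3)ccc21`) gives > 10000 nM as a limit too. Compound 3 (`CCCCCn1c(=O)c(C(=O)O)c(O)c2cc(Cc3ccc(F)cc3)ccc21`) gives > 10000 nM as a limit too. Compound 1 therefore stands at the limit of > 10000 nM in this assay, at which 3 of the 3 values shown sit, and no finer placing is possible. Compound 4 (`CCOC(=O)c1c(O)c2cc(Cc3ccc(F)cc3)ccc2n(C)c1=O`) differs from compound 1 by ethyl in place of hydrogen on an oxygen next to a carbonyl group in a change of carboxy to ethoxycarbonyl. The measured changes lie elsewhere on the shared core and give no size to carry over, being a step that the two limits leave unreadable from compound 1 to compound 2 and a step that the two limits leave unreadable from compound 1 to compound 3 on their two counts. Compound 4 is thus expected to stay near the same limit, with no direction readable. The expected step is a step that the limit leaves unreadable from compound 1 to compound 4 and it remains an estimate. For compound 4 the estimate is 15000 nM with 5000 nM to 50000 nM as the expected range.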

Compound 4, half-maximal cytotoxic concentration: > 10000 nM
Compound 4: only a limit was reported; the forecaster's own chance of this, stated with the estimate: 80%; the middle value does not contradict the limit.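

No step can be read from compound 1 to compound 4, because both values are limits and not numbers: the limit of > 10000 nM in this assay, at which 4 of the 4 values shown sit. The compounds shown leave open whether any change on the shared core would give a measurable value.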